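The source may report more compounds than this note shows. Statements on the series, on what has been measured and on what is new or still open speak of the compounds shown alone.

Working notes on the series. In a functional assay on thoracic aorta for inhibition of Voltage-gated L-type calcium channel (Rattus norvegicus) (on this read-out higher numbers stand for weaker inhibition and lower numbers for stronger inhibition), compound 1 `CC1=NC(C)=C(C(=O)O)C(c2ccccc2[N+](=O)[O-])/C1=C(\O)OC/C=C/c1ccccc1` gives 31 nM. In this assay compound 3 `CC1=NC(C)=C(C(=O)O)C(c2cccc(Cl)c2)/C1=C(\O)OC/C=C/c1ccccc1` gives 20 nM, the lowest of the two numbers shown, and the step of a 1.6-fold lower number from compound 1 to compound 3 (0.19 log units; within the scatter) lies within the scatter. Compound 2 `CC1=NC(C)=C(C(=O)O)C(c2cccc(C(=O)O)c2)/C1=C(\O)OC/C=C/c1ccccc1` sits at a limit of this assay, > 10000 nM. the limit of > 10000 nM in this assay, at which 1 of the 3 values shown sits. Compound 4 `CC1=NC(C)=C(C(=O)O)C(c2cccnc2)/C1=C(\O)OC/C=C/c1ccccc1` differs from compound 3 by pyridin-3-yl in place of 3-chlorophenyl on a saturated ring carbon. Going by the values given here, two measured steps bear on changes of the aryl group on this saturated ring carbon: a 1.6-fold lower number from compound 1 to compound 3 (0.19 log units; within the scatter), small, and an at least 500-fold lower number from compound 2 to compound 3 (2.69 log units; beyond the scatter), large and beyond the scatter. Pyridin-3-yl carries no net charge, unlike nothing measured here; a moderate step upward is expected for compound 4, a 7.5-fold higher number from compound 3 to compound 4 (0.88 log units; beyond the scatter). Compound 4 is estimated at 150 nM, with a range from 30 nM to 800 nM.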

Compound 4, half-maximal inhibitory concentration: 190 nM
Estimate against measurement, compound 4: 1.3-fold (0.10 log units) below; the measured number falls inside the stated range.
By their numbers in this assay, from the lowest: compounds 3 and 1 (each within the scatter of the next); then compound 4. At a limit, above all of these: compound 2.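

A ring with a hetero atom on this saturated ring carbon gives an intermediate result, neither the silent change seen between the two substituted phenyl compounds nor the collapse seen with carboxy: a 9.5-fold higher number from compound 3 to compound 4 (0.98 log units; beyond the scatter) and a 6.1-fold higher number from compound 1 to compound 4 (0.79 log units; beyond the scatter). Pyridin-3-yl also keeps far stronger inhibition than 3-carboxyphenyl, an at least 52-fold lower number from compound 2 to compound 4 (1.72 log units; beyond the scatter). Compound 2 remains a limit and not a number: the limit of > 10000 nM in this assay, at which 1 of the 4 values shown sits.

The compounds shown do not separate the effect of the ring nitrogen from the loss of the chloro. From the compounds shown here alone, what an amine or a methoxy group on the phenyl ring would give remains open.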